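Cytotoxicity notes on compound 2 and compound 3

The source may hold more compounds than are shown below. What is called first, only, known or untested is meant among the compounds shown, and "the series" means these compounds.

Compound 2 `O=C1N(CCCCCCCOc2ccc(Cl)cc2)CCN1c1cccnc1` has been run in a functional assay on cells (Homo sapiens) for cytotoxicity; a lower number here means that less compound is tolerated, a higher number that more compound is tolerated. There compound 2 gives only a limit, > 25000 nM, and not a number. Its companion compound 1 `O=C1N(CCCCCCCOc2ccc(Cl)cc2)CCN1c1ccncc1` was run the same way; compound 1 likewise gives only a limit, > 25000 nM. The step that the two limits leave unreadable from compound 1 to compound 2 is thus not readable in size, and both values sit at the limit of > 25000 nM in this assay, at which 2 of the 2 values shown sit. Compound 2 therefore cannot be placed on a scale of numbers; it stands at the top of what was measured.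

Compound 3 `O=C1N(CCCCCCOc2ccc(F)cc2)CCN1c1cccnc1` is not yet measured in this assay. It differs from compound 2 by 4-fluorophenoxy in place of (4-chlorophenoxy)methyl on a saturated chain carbon, six bonds along the chain from an amide-type nitrogen in a ring. Within the data shown here, the one measured step changed the ring on the amide-type nitrogen, not the chain end, so no measured step bears on this change; only the limits for compound 1 and compound 2 give a reference. For compound 3 the expectation in this assay is again a value at the same limit, the step that the limit leaves unreadable from compound 2 to compound 3 being expected to be none beyond the scatter. Compound 3 is estimated at 30000 nM, with a range from 12000 nM to 100000 nM.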

Compound 3, half-maximal cytotoxic concentration: > 25000 nM
Compound 3: no number, only a limit (the forecaster's own chance of this, stated with the estimate: 85%); the middle value does not contradict the limit.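

In this assay compound 2 and compound 3 both give only limits and no numbers, so no step can be read from compound 2 to compound 3, and the swap of (4-chlorophenoxy)methyl for 4-fluorophenoxy stays without a size: the limit of > 25000 nM in this assay, at which 3 of the 3 values shown sit. The compounds shown leave open whether any change to this series brings a numerical value in this assay.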